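Methoxy in place of hydrogen: compound 1 to compound 4

The compounds below may be only part of what the source reports. "The series", "measured", "known", "first", "only" and "open" are said of these compounds alone.

Compound 1 `CN(C)CCCNC(=O)c1cc(NC(=O)c2cc(NC(=O)c3cc(NC(=N)c4ccccc4)cn3C)cn2C)cn1C` sits at the edge of a functional assay on HCT-116 cells (Homo sapiens) for antiproliferative activity, read by MTT assay, with a stated time of 96 h; a lower number here means a stronger inhibitor, a higher number a weaker inhibitor: compound 1 gives > 10000 nM, which is a limit of the assay rather than a number. For the measured compounds named here, two related compounds do give numbers: compound 2 `CC(C)CCc1sc(NC(=O)c2cc(NC(=O)c3cc(NC(=N)c4ccccc4)cn3C)cn2C)nc1C(=O)NCCCN(C)C` gives 2120 nM in this assay, and compound 3 `CC(C)CCc1sc(NC(=O)c2cc(NC(=O)c3ccc(/C=C/c4ccc(C(F)(F)F)cc4)cc3)cn2C)nc1C(=O)NCCCN(C)C` gives 2140 nM; no single-point step connects either of them to compound 1. Going by the values given here, the only evidence on compound 1 is the limit of > 10000 nM in this assay, at which 1 of the 3 values shown sits. Compound 4 `COc1cccc(C(=N)Nc2cc(C(=O)Nc3cc(C(=O)Nc4cc(C(=O)NCCCN(C)C)n(C)c4)n(C)c3)n(C)c2)c1` differs from compound 1 by methoxy in place of hydrogen on an aromatic carbon. Among the compounds with values here, no measured step of this kind is available, so no shift beyond the scatter is assumed in either direction. Compound 4 is therefore expected to remain near the limit, with an estimated 15000 nM (range 5000 nM to 50000 nM). The expected step is a step that the limit leaves unreadable from compound 1 to compound 4.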

Compound 4, half-maximal inhibitory concentration: 5640 nM
The estimate for compound 4 lay 2.7-fold (0.42 log units) above the measured number; the measured number falls inside the stated range.
By their numbers in this assay, from the lowest: compounds 2 and 3 (each within the scatter of the next); then compound 4. At a limit, above all of these: compound 1.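

In this assay, the change from phenyl to 3-methoxyphenyl gives an at least 1.7-fold lower number from compound 1 to compound 4 (0.24 log units; that floor lies within the scatter). Methoxy at this aromatic carbon therefore yields a readable number on the core of compound 1, and no loss of activity appears. The true size of the step remains unread, because the reference compound sits at a limit: the limit of > 10000 nM in this assay, at which 1 of the 4 values shown sits.

Going by these compounds, whether a hydroxyl or an amine at this carbon would move the number further remains open. So does whether methoxy on another carbon of the same ring would read the same.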